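The source may hold more compounds than are shown below. What is called first, only, known or untested is meant among the compounds shown, and "the series" means these compounds.

Measured so far:
compound 1, `CCCCCOc1ccc2oc(/C=C/[S+](C)[O-])cc(=O)c2c1` – 6600 nM
compound 2, `CCCCOc1ccc2oc(/C=C/[S+](C)[O-])cc(=O)c2c1` – 4800 nM
compound 3, `CC(C)CCOc1ccc2oc(/C=C/[S+](C)[O-])cc(=O)c2c1` – 4100 nM

In a functional assay on DLD-1 cells (Homo sapiens) for cytotoxicity, with a stated time of 48 h (on this read-out higher numbers stand for weaker inhibition and lower numbers for stronger inhibition), compound 1 gives the highest of the three numbers, yet its gaps to the other two both lie within the usual scatter: a 1.4-fold lower number from compound 1 to compound 2 (0.14 log units; within the scatter) and a 1.6-fold lower number from compound 1 to compound 3 (0.21 log units; within the scatter). Compound 4, `COc1ccc2oc(/C=C/[S+](C)[O-])cc(=O)c2c1`, differs from compound 1 by hydrogen in place of butyl on a saturated chain carbon bound to an oxygen on an aromatic ring, so that pentyloxy becomes methoxy. The step that bears on this is the shortening of the same chain, a 1.4-fold lower number from compound 1 to compound 2 (0.14 log units; within the scatter), which did nothing beyond the scatter; the branching step a 1.2-fold lower number from compound 2 to compound 3 (0.07 log units; within the scatter) stayed within it too. Losing the whole butyl is a deeper cut than any tried here, so the step is expected to stay near the scatter, if anything toward a higher number: a 1.1-fold higher number from compound 1 to compound 4 (0.06 log units; within the scatter). Compound 4 is therefore estimated at 7500 nM, with a range from 3000 nM to 19000 nM.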

Compound 4, half-maximal inhibitory concentration: 5700 nM
Estimate against measurement, compound 4: 1.3-fold (0.12 log units) above, and the stated range covers the measured number.
By their numbers in this assay, from the lowest: compounds 3, 2, 4 and 1 (each within the scatter of the next).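

Even the largest cut at this place, on the saturated chain carbon bound to an oxygen on an aromatic ring, stays within the scatter in this assay (a 1.2-fold lower number from compound 1 to compound 4 (0.06 log units; within the scatter)), as do the cuts from the other two chains (a 1.2-fold higher number from compound 2 to compound 4 (0.07 log units; within the scatter); a 1.4-fold higher number from compound 3 to compound 4 (0.14 log units; within the scatter)). Among these four compounds, methoxy therefore cannot be told apart from pentyloxy or the other two chains. No supporting measurement is available to explain this. Going by these compounds, a chain longer than pentyl, an amine or a carboxylic acid at the end of the chain remains open. So does a hydroxyl group in place of methoxy.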